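Removing a Ring Methyl from a Substance-P Antagonist

The compounds below may be only part of what the source reports. "The series", "measured", "known", "first", "only" and "open" are said of these compounds alone.

Compound 1 `Cc1ccccc1-c1nc(N(C)C)nc2c1C(=O)N(Cc1cc(C(F)(F)F)cc(C(F)(F)F)c1)C[C@H](C)CO2` is measured in a functional assay on ileum for antagonist activity at Substance-P receptor (Cavia porcellus) (on this read-out higher numbers stand for weaker inhibition and lower numbers for stronger inhibition), at 0.427 nM. Among the three numbers recorded, compound 1 stands highest. Compound 2 `CC(=O)N1CCN(c2nc3c(c(-c4ccccc4C)n2)C(=O)N(Cc2cc(C(F)(F)F)cc(C(F)(F)F)c2)C[C@H](C)CO3)CC1` gives 0.139 nM in this assay, and compound 3 `CC(=O)N1C(C)CN(c2nc3c(c(-c4ccccc4C)n2)C(=O)N(Cc2cc(C(F)(F)F)cc(C(F)(F)F)c2)C[C@H](C)CO3)CC1C` gives 0.217 nM. The step of a 3.1-fold lower number from compound 1 to compound 2 (0.49 log units; beyond the scatter) is modest but beyond the scatter, while a 2.0-fold lower number from compound 1 to compound 3 (0.29 log units; within the scatter) and a 1.6-fold higher number from compound 2 to compound 3 (0.19 log units; within the scatter) both fall within it. All three of these steps concern the group on an aromatic carbon of the shared core.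

Compound 4 `Cc1ccccc1-c1nc(N(C)C)nc2c1C(=O)N(Cc1cc(C(F)(F)F)cc(C(F)(F)F)c1)CCCO2` differs from compound 1 at a different site: hydrogen in place of methyl on a saturated ring carbon, on a saturated ring carbon of the eight-membered non-aromatic ring with one nitrogen and one oxygen, part of the fused system of two rings. Among the measured compounds shown here, none of the measured steps changes anything on that ring, so no measured step bears on this change, and its size and direction cannot be read from the data. In the absence of any guiding step, the step of a 1.4-fold higher number from compound 1 to compound 4 (0.15 log units; within the scatter) is expected to stay within the scatter, with a wide range allowed. Compound 4 is therefore estimated at 0.6 nM in this assay, with a range from 0.2 nM to 2 nM.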

Compound 4, antagonist equilibrium constant: 0.679 nM
For compound 4 the middle estimate is 1.1-fold (0.05 log units) below the measured one; measured number inside the range.
By their numbers in this assay, from the lowest: compounds 2, 3, 1 and 4 (each within the scatter of the next, the first and the last beyond it).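

With hydrogen in place of methyl on the saturated ring carbon, a 1.6-fold higher number from compound 1 to compound 4 (0.20 log units; within the scatter) in this assay leaves the two compounds indistinguishable on this read-out. Among the compounds shown here, this is the first measured step on the eight-membered non-aromatic ring, as the earlier steps all concerned the group on an aromatic carbon of the shared core, and it shows that with dimethylamino on that aromatic carbon the methyl can be lost without a difference that stands out from the scatter. No supporting measurement is available to account for this result.

The compounds shown leave open whether a longer chain such as ethyl, or a hydroxyl or an amine, on this same saturated ring carbon would also keep the number within the scatter of compound 1, since hydrogen and methyl are the only two substituents seen there. For the compounds shown here, they also leave open whether hydrogen in place of methyl would give a similar result with 4-acetylpiperazin-1-yl in place of dimethylamino on the aromatic carbon, the one group change whose step lies beyond the scatter.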